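The compounds below may be only part of what the source reports. "The series", "measured", "known", "first", "only" and "open" are said of these compounds alone.

Of the compounds shown here, three built on one shared core have been tested in an ADME assay on PBMC cells (Homo sapiens) for cytotoxicity; on this read-out lower numbers stand for higher toxicity in this test and higher numbers for lower toxicity in this test. Compound 1 `Cc1cccc(OC(c2ccc(C(F)(F)F)cc2)C2CCN(C(C)CCNC(=O)c3c(Cl)cncc3Cl)CC2)n1` gives 6700 nM, compound 2 `CC(CCNC(=O)c1c(Cl)cncc1Cl)N1CCC(C(Oc2ccccc2Cl)c2ccc(C(F)(F)F)cc2)CC1` gives 4400 nM, and compound 3 `COC(=O)c1cccc(OC(c2ccc(C(F)(F)F)cc2)C2CCN(C(C)CCNC(=O)c3c(Cl)cncc3Cl)CC2)c1` gives 15200 nM, the highest of the three: a 2.3-fold higher number from compound 1 to compound 3 (0.36 log units; beyond the scatter) and a 3.5-fold higher number from compound 2 to compound 3 (0.54 log units; beyond the scatter). Compound 4 `CC(CCNC(=O)c1c(Cl)cncc1Cl)N1CCC(C(Oc2ccccc2)c2ccc(C(F)(F)F)cc2)CC1` differs from compound 3 by hydrogen in place of methoxycarbonyl on an aromatic carbon. For the measured compounds named here, no measured step removes this group outright, but both steps that brought the 3-(methoxycarbonyl)phenyl group in raised the number, so taking it away is expected to lower the number, back toward the values of compound 1 and compound 2, a step estimated as a 2.5-fold lower number from compound 3 to compound 4 (0.40 log units; beyond the scatter). Compound 4 is therefore expected to give about 6000 nM in this assay, within a range from 2500 nM to 15000 nM.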

Compound 4, half-maximal cytotoxic concentration: 6800 nM
Estimate against measurement, compound 4: 1.1-fold (0.05 log units) below; the measured number falls inside the stated range.
By their numbers in this assay, from the lowest: compounds 2, 1 and 4 (each within the scatter of the next); then compound 3.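

Taking the methoxycarbonyl group off the aromatic ring tests it directly in this assay and lowers the number (a 2.2-fold lower number from compound 3 to compound 4 (0.35 log units; beyond the scatter)), so this group goes with the higher number here. Plain phenyl cannot be told apart from 2-chlorophenyl (a 1.5-fold higher number from compound 2 to compound 4 (0.19 log units; within the scatter)) or from 6-methylpyridin-2-yl (a 1.0-fold higher number from compound 1 to compound 4 (0.01 log units; within the scatter)), which leaves compound 3 alone in standing apart. No supporting data explain this shift. Still open, from the compounds shown here alone, is whether a carboxylic acid or a primary amide in this place would raise the number as methoxycarbonyl does.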